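Series notes: configuration change from compound 3 to compound 4

The source may report more compounds than this note shows. Statements on the series, on what has been measured and on what is new or still open speak of the compounds shown alone.

Three compounds have numbers in an ADME assay on RD cells (Homo sapiens) for cytotoxicity, read by MTT assay, with a stated time of 3 days; a higher number here means that more compound is tolerated, a lower number that less compound is tolerated. Compound 1 `CC[C@@H](CCn1cncn1)c1ccc(Cl)cc1` gives 55.3 ug/mL and compound 2 `CCCC[C@@H](CCn1cncn1)c1ccccc1` gives 47.5 ug/mL. Compound 3 `CCCC[C@H](CCn1cncn1)c1ccc(Cl)cc1` gives 20.3 ug/mL, the lowest of the three and beyond the scatter from both compound 2 and compound 1, so compound 3 is the least tolerated of them. Compound 4 `CCCC[C@@H](CCn1cncn1)c1ccc(Cl)cc1` is not yet measured. Its difference from compound 3: the two compounds have the same atoms and bonds and differ only in configuration as drawn: 1 of 1 stereo elements differ; a stereocentre at a saturated chain carbon is drawn R in compound 3 and S in compound 4. Among the measured compounds shown here, no step between measured compounds isolates a change in configuration alone, so nothing here shows the size of such a step; the expected step is a 1.2-fold higher number from compound 3 to compound 4 (0.07 log units; within the scatter), none beyond the scatter. On that basis compound 4 is estimated at 24 ug/mL, with a range from 11 ug/mL to 50 ug/mL.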

Compound 4, half-maximal cytotoxic concentration: 18.7 ug/mL
Beside the measured number, compound 4's estimate is 1.3-fold (0.11 log units) above it; the range from low to high includes it.
By their numbers in this assay, from the lowest: compounds 4 and 3 (each within the scatter of the next); then compounds 2 and 1 (each within the scatter of the next).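

In this assay, configuration at the saturated chain carbon now has its own step, a 1.1-fold lower number from compound 3 to compound 4 (0.04 log units; within the scatter), so this inversion leaves the number within the scatter, and the reading is clean: the fact that compounds 3 and 4 differ only in the configuration as drawn. Holding the S configuration, there is a 2.5-fold lower number from compound 2 to compound 4 (0.40 log units; beyond the scatter) for chloro in place of hydrogen on an aromatic carbon. For ethyl in place of hydrogen on a saturated chain carbon, there is a 3.0-fold lower number from compound 1 to compound 4 (0.47 log units; beyond the scatter), and both steps lie beyond the scatter.

Going by these compounds, whether configuration stays this silent in compounds without the chloro remains open. So does the effect of a longer chain, or of a nitrile in place of chloro.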